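This account rests on a few compounds, and the source may have more. Where it says the series, first, only, none or still open, it means among the compounds named here.

In an ADME assay (liver) for metabolic stability, with Liver microsome (Homo sapiens) as the target, using microsomes and NADPH, with a stated time of 30 min, tested at 1 uM (on this read-out lower numbers stand for slow clearance and higher numbers for fast clearance), three compounds that share one core have been measured. Compound 1 `COCC#Cc1cc(C(O)(C(F)(F)F)C(F)(F)F)cnc1N1CCN(S(=O)(=O)c2ccc(N)nc2)CC1` gives 15 mL.min-1.g-1, and compound 2 `Nc1ccc(S(=O)(=O)N2CCN(c3ncc(C(O)(C(F)(F)F)C(F)(F)F)cc3-c3cnccc3F)CC2)cn1` gives 17 mL.min-1.g-1. Compound 3 `Nc1ccc(S(=O)(=O)N2CCN(c3ncc(C(O)(C(F)(F)F)C(F)(F)F)cc3-c3ccc4ocnc4c3)CC2)cn1` has no exact number and is reported only as a limit, < 14 mL.min-1.g-1.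

Compound 4 `Nc1ccc(S(=O)(=O)N2CCN(c3ncc(C(O)(C(F)(F)F)C(F)(F)F)cc3-c3cc4ccccc4[nH]3)CC2)cn1` differs from compound 3 at one place, an aromatic carbon of a six-membered aromatic ring with 1 nitrogen, where 1H-indol-2-yl stands in place of 1,3-benzoxazol-5-yl (1H-indol-2-yl in place of 1,3-benzoxazol-5-yl on an aromatic carbon).

Three measured steps exchange the group at this same place: a 1.1-fold higher number from compound 1 to compound 2 (0.05 log units; within the scatter), an at least 1.0-fold lower number from compound 1 to compound 3 (0.02 log units; that floor lies within the scatter) and an at least 1.2-fold lower number from compound 2 to compound 3 (0.08 log units; that floor lies within the scatter). All three lie within the scatter, though the last two are only floors, since they end on a limit. None of them tests 1H-indol-2-yl itself. On these three steps, no change beyond the scatter is expected in this assay. The expected size of the change is an at least 1.1-fold higher number from compound 3 to compound 4 (0.05 log units; that floor lies within the scatter). For compound 4 the estimated value is 16 mL.min-1.g-1, with an expected range of 11 mL.min-1.g-1 to 30 mL.min-1.g-1.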

Compound 4, intrinsic clearance in microsomes: < 14 mL.min-1.g-1
Compound 4: a limit, no number; the forecaster's own chance of this, stated with the estimate: 40%; at least 1.1-fold (0.05 log units) between middle value and limit.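

In this assay compound 4 is reported only as a limit, < 14 mL.min-1.g-1. So a second two-ring group at this aromatic carbon, 1H-indol-2-yl, which carries a hydrogen-bond donor where 1,3-benzoxazol-5-yl carries none, also ends at a limit, and the floors of the two readable steps, an at least 1.2-fold lower number from compound 2 to compound 4 (0.08 log units; that floor lies within the scatter) and an at least 1.0-fold lower number from compound 1 to compound 4 (0.02 log units; that floor lies within the scatter), both stay within the scatter. The step between compound 3 and compound 4 cannot be read because both compounds sit at the same limit: the limit of < 14 mL.min-1.g-1 in this assay, at which 2 of the 4 values shown sit.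

From the compounds shown here alone, how far the true clearance of either compound lies from that limit stays open, so no order between the two can be given. Also open, going by these compounds, is what an amine, a carboxylic acid or a plain phenyl group would give at this same aromatic carbon.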